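A Methyl Branch on the Linker Chain

A few compounds are considered here, and "the series" means these few. Any claim that something is new, unique, unknown or untested is made for them only; others in the source may bear on it.

Compound 1, `COc1ccc(-n2nc(Sc3ccc(Cl)cc3)cc(CCC(=O)N[C@@H]3CCc4ccccc4NC3=O)c2=O)cc1`: 34%
Compound 2, `COc1ccc(-n2nc(Sc3ccc(Cl)cc3)cc(CCCNC(=O)[C@H]3CCNC[C@@H]3c3ccccc3)c2=O)cc1`: 28%
Compound 3, `COc1ccc(-n2nc(Sc3ccc(Cl)cc3)cc(CCCNC(=O)[C@H]3CNC[C@@H]3c3ccccc3)c2=O)cc1`: 22%

These three compounds share one core and were tested in a functional assay with Melanocortin receptor 4 (Homo sapiens) as the target, read by cAMP accumulation; on this read-out lower numbers stand for smaller maximal responses and higher numbers for larger maximal responses. In this assay compound 2 gives 28%, the second highest of the three numbers, with compound 1 and compound 3 each within the scatter of it, so the three values cannot be told apart. Compound 4 `COc1ccc(-n2nc(Sc3ccc(Cl)cc3)cc(CCC(C)NC(=O)[C@H]3CCNC[C@@H]3c3ccccc3)c2=O)cc1` differs from compound 2 by methyl in place of hydrogen on a saturated chain carbon bound to an amide-type nitrogen and a saturated chain carbon. Going by the values given here, the only measured step, a number 6 percentage points lower from compound 2 to compound 3 (within the scatter), swaps the ring on the carbonyl carbon, not the chain, and stayed within the scatter; no measured step touches the chain itself. Compound 4 is therefore expected to give a step of no change at the digits printed from compound 2 to compound 4 (within the scatter), nothing beyond the scatter. For compound 4 the estimate is 28%, between 15% and 42%.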

Compound 4, largest response reached (reported as maximum), in percent of the reference or control that the assay uses: 79%
Beside the measured number, compound 4's estimate is 51 percentage points below it; measured number outside the range, above it.
By their numbers in this assay, from the lowest: compounds 3, 2 and 1 (each within the scatter of the next, the first and the last beyond it); then compound 4.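

In this assay, methyl in place of hydrogen on this saturated chain carbon gives a number 51 percentage points higher from compound 2 to compound 4 (beyond the scatter) and so shows that the linker chain is a sensitive position. The earlier step, a number 6 percentage points lower from compound 2 to compound 3 (within the scatter), changed the ring on the carbonyl carbon and gave no such sign. No available evidence explains this rise. From the compounds shown here alone, whether an ethyl group or a hydroxyl group on the same carbon would give a similar response remains open. So does whether the methyl would have the same effect on compound 3.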